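The compounds below may be only part of what the source reports. "The series", "measured", "known", "first", "only" and "open" are said of these compounds alone.

Compound 1 `Cc1cn([C@H]2C[C@H](CF)[C@@H](CO)O2)c(=O)[nH]c1=O`: > 100 uM (a limit)
Compound 2 `Cc1cn([C@@H]2O[C@H](CO)[C@@H](CN)[C@@H]2O)c(=O)[nH]c1=O`: > 100 uM (a limit)

Both entries come from a functional assay on P388 cells (Mus musculus) for antiproliferative activity, with a stated time of 72 h; on this read-out lower numbers stand for an effect already at smaller amounts and higher numbers for an effect only at larger amounts of compound. Compound 2 stands only at a limit, > 100 uM, and has no exact number. Compound 3 `Cc1cn([C@H]2C[C@H](CN)[C@@H](CO)O2)c(=O)[nH]c1=O` differs from compound 2 by one change, hydrogen in place of hydroxy on a saturated ring carbon. Going by the values given here, no step between measured compounds is available to size this change. Resting on compound 2 and on (the limit of > 100 uM in this assay, at which 2 of the 2 values shown sit), the expected step in this assay is a number no higher from compound 2 to compound 3 (the limit leaves the size open), with none expected beyond the scatter. Compound 3 is estimated at 100 uM, with an expected range of 30 uM to 300 uM.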

Compound 3, concentration for half-maximal effect: > 100 uM
Compound 3 gave a limit, no number; the forecaster's own chance of this, stated with the estimate: 70%; the middle value lies on the limit itself.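

No step can be read from compound 2 to compound 3 or from compound 1 to compound 3, because all the values are limits: the limit of > 100 uM in this assay, at which 3 of the 3 values shown sit.

The compounds shown leave open how large either change is in this assay.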